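Replacing iodo with ethyl on the carbamate aryl ring

The source may report more compounds than this note shows. Statements on the series, on what has been measured and on what is new or still open speak of the compounds shown alone.

Compound 1 `C=C1C(=O)OC[C@H]1CCOC(=O)Nc1ccc(I)cc1` gives 12800 nM in an ADME assay on RAW264.7 cells (Mus musculus) for cytotoxicity, read by MTT assay, with a stated time of 18 h; on this read-out lower numbers stand for higher toxicity in this test and higher numbers for lower toxicity in this test. Compound 2 `C=C1C(=O)OC[C@@H]1CCOC(=O)Nc1ccc(I)cc1` gives 12500 nM in this assay, and compound 3 `C=C1C(=O)OC[C@@H]1CCOC(=O)Nc1ccccc1F` gives 24200 nM. Compound 2 has the lowest number of the three, yet its gaps to compound 1 and to compound 3 both lie within the scatter. For the measured compounds named here, the only single-site step measured, a 1.0-fold lower number from compound 1 to compound 2 (0.01 log units; within the scatter), rests on the fact that compounds 1 and 2 differ only in the configuration as drawn and so says nothing about the aryl substituent. Compound 4 `C=C1C(=O)OC[C@@H]1CCOC(=O)Nc1ccc(CC)cc1` differs from compound 2 by ethyl in place of iodo on an aromatic carbon. Going by the values given here, no measured step covers such an exchange, and the gap between compound 2 and compound 3 stays within the scatter, so no step beyond the scatter is expected: compound 4 is estimated at 13000 nM, range 6500 nM to 26000 nM, a step of a 1.0-fold higher number from compound 2 to compound 4 (0.02 log units; within the scatter).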

Compound 4, half-maximal cytotoxic concentration: 7580 nM
Compound 4: middle estimate off by 1.7-fold (0.23 log units), on the high side; the range from low to high includes it.
By their numbers in this assay, from the lowest: compounds 4, 2, 1 and 3 (each within the scatter of the next, the first and the last beyond it).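

At this place, on an aromatic carbon para to a large group, ethyl in place of iodo gives a 1.6-fold lower number from compound 2 to compound 4 (0.22 log units; within the scatter) in this assay. This is the only exchange of a group at this place among the compounds shown, and it stays inside the scatter of the read-out. No information given here bears on the cause of this step. On these data alone, whether an amine, a carboxylic acid or a longer chain at this place would give a step beyond the scatter remains open. So does whether the configuration as drawn matters once ethyl stands there.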